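The source may hold more compounds than are shown below. What is called first, only, known or untested is meant among the compounds shown, and "the series" means these compounds.

Of the compounds shown here, two of a shared core have so far been measured in a physicochemical assay for metabolic stability, read by HPLC, tested at 2 mM; a higher number here means that the compound lasts longer, a lower number that the compound disappears faster. Compound 1 `O=C(O[C@H]1C[C@H](n2cc(F)c(=O)[nH]c2=O)O[C@@H]1COP(=O)(O)Oc1ccccc1)c1ccccc1` gives 6.6 h in this assay. Within the data shown here, compound 2 `O=c1[nH]c(=O)n([C@H]2C[C@H](O)[C@@H](COP(=O)(O)Oc3ccccc3)O2)cc1F` gives 28 h, the higher of the two numbers; the single step between them, a 4.2-fold higher number from compound 1 to compound 2 (0.63 log units; beyond the scatter), concerns hydrogen in place of benzoyl on an oxygen on a saturated carbon. Compound 3 `O=c1[nH]c(=O)n([C@H]2C[C@H](O)[C@@H](COP(=O)(O)Oc3ccc4ncccc4c3)O2)cc1F` has not yet been measured in this assay. It differs from compound 2 in one place: quinolin-6-yl in place of phenyl on an oxygen. Among the measured compounds shown here, no measured step touches the group on the oxygen whose other neighbour is phosphorus; the one step that exists changes a different part of the molecule, so it gives no guidance on how this assay answers to quinolin-6-yl in place of phenyl. For the measured compounds named here, with no comparable step to draw on, the expectation for compound 3 is a number close to that of compound 2, within the scatter, so the expected step is no change at the digits printed from compound 2 to compound 3 (within the scatter). Compound 3 is therefore estimated at 28 h, with a range from 10 h to 75 h that is kept wide to allow for the untested change.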

Compound 3, half-life: 26 h
The estimate for compound 3 lay 1.1-fold (0.03 log units) above the measured number, within the range that was stated.
By their numbers in this assay, from the lowest: compound 1; then compounds 3 and 2 (each within the scatter of the next).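

Among these compounds, at the oxygen whose other neighbour is phosphorus, the first reading in this assay is a 1.1-fold lower number from compound 2 to compound 3 (0.03 log units; within the scatter) and so does not separate quinolin-6-yl from phenyl. The entering group brings a second six-membered aromatic ring, one that contains nitrogen, along with a hydrogen-bond acceptor, yet this larger group leaves compound 3 indistinguishable from compound 2 in this read-out, whereas the change at the other site, a 4.2-fold higher number from compound 1 to compound 2 (0.63 log units; beyond the scatter), does register beyond the scatter. Nothing measured here offers an explanation for this result.

Phenyl and quinolin-6-yl are both aromatic groups, so it remains open whether a group of another kind on this oxygen, such as a simple ethyl chain or a phenyl ring carrying an amine or a carboxylic acid, would give a number as close to that of compound 2. It is also open whether quinolin-6-yl would behave in the same way when benzoyl sits on the oxygen on a saturated carbon, as it does in compound 1, since the two changes are not seen together in any compound shown here.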